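The compounds below may be only part of what the source reports. "The series", "measured", "known", "first", "only" and "open" are said of these compounds alone.

In an ADME assay on Vero cells (Chlorocebus sabaeus) for cytotoxicity, read by MTT assay, with a stated time of 72 h (on this read-out higher numbers stand for lower toxicity in this test and lower numbers for higher toxicity in this test), compound 1 (`COc1c(N2C[C@H]3CCCN(C(=O)Cn4cc(CN5C(=O)/C(=N/O)c6ccccc65)nn4)[C@H]3C2)c(F)cc2c(=O)c(C(=O)O)cn(C3CC3)c12`) gives 32 ug/mL as its reading, and compound 2 (`COc1c(N2C[C@H]3CCCN(C(=O)Cn4cc(CN5C(=O)/C(=N/O)c6cc(F)ccc65)nn4)[C@H]3C2)c(F)cc2c(=O)c(C(=O)O)cn(C3CC3)c12`) gives 16 ug/mL as its reading. For the measured compounds named here, these are the only two numbers so far, and they lie within the scatter of each other, so compound 1 has no clear place above or below its one neighbour. Going by the values given here, the single measured step is a 2.0-fold lower number from compound 1 to compound 2 (0.30 log units; within the scatter) and it comes with fluoro in place of hydrogen on an aromatic carbon.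

Compound 3 (`CO/N=C1/C(=O)N(Cc2cn(CC(=O)N3CCC[C@@H]4CN(c5c(F)cc6c(=O)c(C(=O)O)cn(C7CC7)c6c5OC)C[C@@H]43)nn2)c2ccccc21`) differs from compound 1 by methyl in place of hydrogen on an oxygen and so turns hydroxy to methoxy, on an oxygen whose other neighbour is a double-bonded nitrogen. Among the compounds with values here, no measured pair carries this change, and the fluoro step lies in another place, so it is only a loose guide to size. With that one step, a 2.0-fold lower number from compound 1 to compound 2 (0.30 log units; within the scatter), inside the scatter, no shift beyond the scatter is expected in this assay and no direction can be favoured. The expected step is no change at the digits printed from compound 1 to compound 3 (within the scatter) on this estimate. For compound 3 the estimated value is 32 ug/mL with an expected range from 12 ug/mL to 85 ug/mL for this reading.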

Compound 3, half-maximal cytotoxic concentration: 128 ug/mL
Compound 3: the middle estimate sits 4.0-fold (0.60 log units) below what was measured, outside the stated range (above it).
By their numbers in this assay, from the lowest: compounds 2 and 1 (each within the scatter of the next); then compound 3.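

In this assay the change of hydroxy to methoxy, methyl in place of hydrogen on an oxygen whose other neighbour is a double-bonded nitrogen, brings a 4.0-fold higher number from compound 1 to compound 3 (0.60 log units; beyond the scatter) and so gives the only step shown that lies beyond the scatter, a modest one. This oxygen is therefore a place where a single added methyl moves the reading measurably, towards the higher numbers that stand for lower toxicity in this test, whereas the fluoro step on an aromatic carbon stayed within the scatter. Nothing at hand explains why the reading moves.

The compounds shown leave open whether any group on this oxygen would raise the reading or whether the result belongs to methyl alone, a question that an ethoxy group, a longer chain or an acetyl group on the same oxygen would address. They also leave open whether the methoxy and the fluoro changes would read the same when carried together on the shared core, and whether the reading would hold with an amine in place of the oxime oxygen.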